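The source may report more compounds than this note shows. Statements on the series, on what has been measured and on what is new or still open speak of the compounds shown alone.

Compound 1 `COCC(C)(C)C#Cc1c(Cl)c2c(Cl)cc(C(N)=O)nc2n1[C@H]1CCCNC1` gives 219 nM in a functional assay on KG-1 cells (Homo sapiens) for antiproliferative activity (a lower number here means that less compound is needed, a higher number that more compound is needed for the effect), the lower of the two numbers recorded there; compound 2 `NC(=O)c1cc(Cl)c2c(Cl)c(C#CCO)n([C@H]3CCCNC3)c2n1` gives 301 nM, so the step of a 1.4-fold higher number from compound 1 to compound 2 (0.14 log units; within the scatter) is the only one that bears on the change now considered. Compound 3 `CC(O)CC#Cc1c(Cl)c2c(Cl)cc(C(N)=O)nc2n1[C@H]1CCCNC1` differs from compound 1 in that (2-hydroxypropyl in place of 1-(methoxymethyl)-1-methylethyl on a triple-bonded carbon). Going by the values given here, since the one comparable change on that triple-bonded carbon stayed within the scatter, compound 3 is expected to show a step of a 1.1-fold higher number from compound 1 to compound 3 (0.06 log units; within the scatter), none beyond the scatter. The estimate for compound 3 is therefore 250 nM, within 120 nM to 520 nM.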

Compound 3, half-maximal effective concentration: 48 nM
Compound 3: the middle estimate sits 5.2-fold (0.72 log units) above what was measured; the measured number lies below the stated range.
By their numbers in this assay, from the lowest: compound 3; then compounds 1 and 2 (each within the scatter of the next).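

In this assay, the group on the triple-bonded carbon can move the number beyond the scatter: 2-hydroxypropyl in place of 1-(methoxymethyl)-1-methylethyl gives a 4.6-fold lower number from compound 1 to compound 3 (0.66 log units; beyond the scatter) in this series. Hydroxy alone does not set the number, since compound 2 also carries one, and 1-hydroxyethyl in place of its hydroxy gives a 6.3-fold lower number from compound 2 to compound 3 (0.80 log units; beyond the scatter) on the saturated chain carbon. Nothing available explains this drop.

On these data alone, whether an amine in place of the hydroxy of 2-hydroxypropyl would hold the lower number stays open. So does the effect of a longer chain carrying that hydroxy.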